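The source may hold more compounds than are shown below. What is called first, only, known or untested is meant among the compounds shown, and "the series" means these compounds.

Measured so far:
Compound 1 `CCCCOC(=N)NC(=N)Nc1ccc(Cl)cc1` gives 3.32
Compound 2 `CCCCCCCCNC(=N)NC(=N)Nc1ccc(Cl)cc1` gives 5.13

Both compounds were measured in a physicochemical assay for lipophilicity, in phosphate buffer, measured as octanol-water partition, at pH 11.5; on this read-out higher numbers stand for higher lipophilicity and lower numbers for lower lipophilicity. Compound 2 at 5.13 stands highest of the two, and compound 1 at 3.32 lies lower by a gap beyond the usual scatter.

Compound 3 `CCCNC(=N)NC(=N)Nc1ccc(Cl)cc1` has not yet been measured. Its change from compound 2 is counted as hydrogen in place of pentyl on a saturated chain carbon, three bonds along the chain from an amine nitrogen and, in words, it is hydrogen in place of pentyl on a saturated chain carbon, three bonds along the chain from an amine nitrogen.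

Among the compounds with values here, no measured pair differing in one place is available, so the size of this change has no direct guide. A large downward step in this assay is nevertheless expected, well beyond the scatter. The only measured span to set beside it is the gap down to compound 1 at 3.32 in this small set, and the expectation is that compound 3 will land somewhat under that number. The estimated move is a number 2.43 log units lower from compound 2 to compound 3 (beyond the scatter) and it remains a judgement. Compound 3 is estimated at 2.7 with a range of 2.2 to 3.2 expected for the measurement.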

Compound 3, partition coefficient: 2.63
Compound 3: the middle estimate sits 0.07 log units above what was measured, and the stated range covers the measured number.
By their numbers in this assay, from the lowest: compound 3; then compound 1; then compound 2.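

In this assay the saturated chain carbon three bonds along the chain from an amine nitrogen now has its first measured change: hydrogen in place of pentyl gives a number 2.50 log units lower from compound 2 to compound 3 (beyond the scatter) as a large step, so the read-out responds strongly to this change at this place. Propylamino in place of butoxy on a carbon with a double bond to nitrogen gives a number 0.69 log units lower from compound 1 to compound 3 (beyond the scatter) as a modest step that still lies beyond the usual scatter, though this swap alters the linking atom and the chain together and a single step cannot divide its size between them. Nothing among the data offers an explanation for either step.

Within the data shown here, the large step spans only two chain lengths, so it remains open whether intermediate chains would fall evenly between them, and whether a chain ending in a carboxylic acid or an amine would follow the same course. A butylamino group in place of butoxy would separate the linking atom from the chain length, and the compounds shown leave that split unresolved.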